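This account rests on a few compounds, and the source may have more. Where it says the series, first, only, none or still open, it means among the compounds named here.

Measured so far:
compound 1 `CCCNc1nc(N)nc2c1ncn2/C=C1/CC1(CO)CO` — > 20000 nM
compound 2 `CCCSc1nc(N)nc2c1ncn2/C=C1/CC1(CO)CO` — > 20000 nM
compound 3 `Nc1nc2c(ncn2/C=C2/CC2(CO)CO)c(=O)[nH]1` — > 20000 nM

In an ADME assay on BCBL1 cells (Homo sapiens) for cytotoxicity, with a stated time of 7 days (on this read-out higher numbers stand for lower toxicity in this test and lower numbers for higher toxicity in this test), compound 1 is reported only as the limit > 20000 nM. Compound 2 likewise reaches the limit > 20000 nM in this assay. Compound 3 also stands at a limit, > 20000 nM. Compound 2 therefore stands exactly where every other value in this set stands: the limit of > 20000 nM in this assay, at which 3 of the 3 values shown sit. Among the compounds with values here, the one step between measured compounds, a step that the two limits leave unreadable from compound 1 to compound 2, puts propylsulfanyl in place of propylamino on an aromatic carbon; its size cannot be read, both ends being limits.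

Compound 4 `Nc1nc(SC2CCCC2)c2ncn(/C=C3/CC3(CO)CO)c2n1` differs from compound 2 by cyclopentyl in place of propyl on a sulfur. Within the data shown here, no measured step bears on that change directly; the only step on record, a step that the two limits leave unreadable from compound 1 to compound 2, alters the group on the aromatic carbon, not the chain on sulfur. Given that all three values sit at the limit (the limit of > 20000 nM in this assay, at which 3 of the 3 values shown sit), the expectation for compound 4 is another value at or near the limit. The step expected for compound 4 is a step that the limit leaves unreadable from compound 2 to compound 4, nothing beyond the scatter. Compound 4 is estimated at 30000 nM, with a range from 12000 nM to 80000 nM and a strong chance that only a limit is reported.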

Compound 4, half-maximal cytotoxic concentration: > 20000 nM
Compound 4 ended at the assay's limit (the forecaster's own chance of this, stated with the estimate: 80%); the middle value is on the limit's open side.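

The steps to compound 4 from compound 1 and from compound 2 cannot be read, because the values in this assay are all limits: the limit of > 20000 nM in this assay, at which 4 of the 4 values shown sit. The compounds shown leave open at what concentration any of them becomes toxic to these cells, and whether propylamino, propylsulfanyl or cyclopentylsulfanyl on the shared core changes that concentration.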